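The source may report more compounds than this note shows. Statements on the series, on what has been measured and on what is new or still open speak of the compounds shown alone.

In a functional assay on HL-60 cells (Homo sapiens) for cytotoxicity, read by luminescence and CellTiter-Glo, with a stated time of 3 days (on this read-out lower numbers stand for stronger inhibition and higher numbers for weaker inhibition), compound 1 (`N#Cc1ccc(NC(=O)c2ccc(C(F)(F)F)cc2O)cc1`) gives 1030 nM and is the only one of the three tested compounds to return a number. Compound 2 (`N#Cc1ccc(NC(=O)c2c(O)cccc2F)cc1`) gives > 10000 nM as a limit and not as a number. Compound 3 (`N#Cc1ccc(NC(=O)c2ccc[nH]c2=O)cc1`) likewise gives > 10000 nM as a limit and not as a number. Among the compounds with values here, that leaves compound 1 as the single measured point, while the rest of the tested set rests on the limit of > 10000 nM in this assay, at which 2 of the 3 values shown sit, and no step between measured compounds can be sized.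

Compound 4 (`N#Cc1ccc(NC(=O)c2ccc(Br)cc2O)cc1`) keeps the core of compound 1 and carries bromo in place of trifluoromethyl on an aromatic carbon, meta to a hydroxy group and para to a large group (bromo in place of trifluoromethyl on an aromatic carbon). Within the data shown here, no measured pair isolates this change. In this assay a small step toward weaker inhibition is expected, probably no larger than the usual scatter, with compound 1 at 1030 nM as the only anchor. The estimated change is a 1.5-fold higher number from compound 1 to compound 4 (0.16 log units; within the scatter) and it remains an expectation only. For compound 4 the expected value is 1500 nM with an estimated range from 500 nM to 5000 nM as the likely span.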

Compound 4, half-maximal inhibitory concentration: 1210 nM
For compound 4 the middle estimate is 1.2-fold (0.09 log units) above the measured one, within the range that was stated.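

With this result, the place on the aromatic carbon, meta to a hydroxy group and para to a large group, has its first sized step in this assay: a 1.2-fold higher number from compound 1 to compound 4 (0.07 log units; within the scatter), for bromo in place of trifluoromethyl. Compound 1 and compound 4 therefore give two measured points that this read-out cannot tell apart, and neither group can be ranked over the other, although one bromine atom has taken the place of a group of carbon and fluorine atoms. Compound 2 and compound 3 each stay a limit and not a number, so the steps to them cannot be read: the limit of > 10000 nM in this assay, at which 2 of the 4 values shown sit.

What the compounds shown leave open is how this place would respond to a group of another kind, such as an amine, a carboxylic acid or a longer chain, as trifluoromethyl and bromo are the only two groups with numbers there. On these data alone, it is equally open what a methoxy group in place of the hydroxy group would do to the number in this assay, with trifluoromethyl or bromo kept.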